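The source may hold more compounds than are shown below. What is called first, only, known or untested is meant among the compounds shown, and "the series" means these compounds.

Working notes on the series. Of the compounds shown here, two have been measured in an ADME assay on L1210 cells (Mus musculus) for inhibition, read by cell counting; on this read-out higher numbers stand for weaker inhibition and lower numbers for stronger inhibition. Compound 1 `CSc1nc(OCCCNc2ccnc3cc(Cl)ccc23)c(C#N)c(-c2ccccc2)n1` gives 3900 nM in this assay. Compound 2 `CSc1nc(NCCCCNc2ccnc3cc(Cl)ccc23)c(C#N)c(-c2ccc([N+](=O)[O-])cc2)n1` gives 960 nM in this assay, the lower of the two numbers, with compound 1 standing a good way above it, beyond the scatter. For the measured compounds named here, these two differ in more than one place, so no single step between them is defined; only the two values themselves can be set side by side.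

Compound 3 `COc1ccc(-c2nc(SC)nc(NCCCCNc3ccnc4cc(Cl)ccc34)c2C#N)cc1OC` is not yet measured. It differs from compound 2 by 3,4-dimethoxyphenyl in place of 4-nitrophenyl on an aromatic carbon. Going by the values given here, no measured pair isolates an exchange of this kind, so the size of the step is open; the expectation is a small move, if any, toward a somewhat higher number, not clearly beyond the scatter. On that basis compound 3 is estimated at 1500 nM in this assay, with a range of 500 nM to 5000 nM. This estimate corresponds to an expected 1.6-fold higher number from compound 2 to compound 3 (0.19 log units; within the scatter).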

Compound 3, half-maximal inhibitory concentration: 18000 nM
Compound 3: middle estimate off by 12-fold (1.08 log units), on the low side; measured number above the stated range.
By their numbers in this assay, from the lowest: compound 2; then compound 1; then compound 3.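

In this assay, for the compounds shown here, the aryl group on the aromatic carbon ortho to a cyano group proves to matter: with the rest of the molecule unchanged, 3,4-dimethoxyphenyl in place of 4-nitrophenyl gives a 19-fold higher number from compound 2 to compound 3 (1.27 log units; beyond the scatter) and is the first single-place step. The exchange leaves a six-membered aromatic ring of carbon only at this position and the same count of hydrogen-bond acceptors, so those shared counts do not keep the numbers close.

Open, on these data alone, is whether the step follows the loss of the nitro group, the entry of the two methoxy groups, or both, and a single 4-methoxyphenyl or 3-methoxyphenyl would separate these. Also open, as far as these compounds go, is how 4-chlorophenyl or a pyridyl ring would stand at this position. Going by these compounds alone, nothing measured so far accounts for the size of this step.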